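Inverting the Ring Methyl Centre in Compound 4

The compounds below may be only part of what the source reports. "The series", "measured", "known", "first", "only" and "open" are said of these compounds alone.

Compound 1, `CC(=O)N1CCN(c2cc(-c3cc(Cl)c4c(N)ncnn34)ccc2S(C)(=O)=O)C(=O)C1(C)C`: 84%
Compound 2, `CC(=O)N1CCN(c2cc(-c3cc(Cl)c4c(N)ncnn34)ccc2C#N)C(=O)C1(C)C`: 89%
Compound 3, `CC(=O)N1C[C@@H](C)N(c2cc(-c3cc(Cl)c4c(N)ncnn34)ccc2C#N)C(=O)C1(C)C`: 22%

In an ADME assay on microsomes from liver (Mus musculus) for metabolic stability, read by LC-MS, using NADPH, with stated times of 6 min and 10 min, tested at 0.5 uM (on this read-out higher numbers stand for a more stable compound and lower numbers for a less stable compound), compound 3 stands lowest of the three measured numbers; its nearest neighbour is compound 1, and its furthest is compound 2, both beyond the scatter. The step of a number 5 percentage points higher from compound 1 to compound 2 (within the scatter) is within the scatter, whereas the step of a number 67 percentage points lower from compound 2 to compound 3 (beyond the scatter) is large. Compound 4, `CC(=O)N1C[C@H](C)N(c2cc(-c3cc(Cl)c4c(N)ncnn34)ccc2C#N)C(=O)C1(C)C`, is not yet measured. Its relation to compound 3 is the two compounds have the same atoms and bonds and differ only in configuration as drawn: 1 of 1 stereo elements differ; a stereocentre at a saturated ring carbon is drawn R in compound 3 and S in compound 4. For the measured compounds named here, no measured step concerns a change in configuration alone, so none bears directly on this one; the step of a number 67 percentage points lower from compound 2 to compound 3 (beyond the scatter) only shows that the ring methyl as drawn in compound 3 goes with a large drop from compound 2. The mirror arrangement in compound 4 could sit anywhere between the numbers of compound 2 and compound 3. The expectation for compound 4 in this assay is 40%, within 12% to 80%, which would be an estimated step of a number 18 percentage points higher from compound 3 to compound 4 (beyond the scatter).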

Compound 4, percent of the compound remaining: 85%
For compound 4 the middle estimate is 45 percentage points below the measured one, outside the stated range (above it).
By their numbers in this assay, from the lowest: compound 3; then compounds 1, 4 and 2 (each within the scatter of the next).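

In this assay, inverting the stereocentre at the saturated ring carbon gives a number 63 percentage points higher from compound 3 to compound 4 (beyond the scatter), and this large change can be assigned to that centre alone because of one fact: the fact that compounds 3 and 4 differ only in the configuration as drawn. Adding the ring methyl with the centre drawn S gives a number 4 percentage points lower from compound 2 to compound 4 (within the scatter), so methyl in place of hydrogen at this carbon does not by itself go with a loss in this read-out. The large drop seen earlier therefore goes with the methyl drawn R, not with the methyl as such.

The compounds shown leave open whether a larger or different group at this ring carbon, such as an ethyl or a hydroxymethyl, would show the same dependence on configuration. They also do not tell which part of compound 3 is lost in the assay.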